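Dichloropurine ribosides and acetylated analogues in HL-60 cells

The source may hold more compounds than are shown below. What is called first, only, known or untested is meant among the compounds shown, and "the series" means these compounds.

Compound 1 `OC[C@@H](O)[C@H]1O[C@@H](n2cnc3c(Cl)nc(Cl)nc32)[C@H](O)[C@@H]1O` in a functional assay on HL-60 cells (Homo sapiens), read by colorimetric assay, with a stated time of 24 h; a lower number here means a stronger inhibitor, a higher number a weaker inhibitor: compound 1 gives > 100000 nM, a limit of the assay.
Compound 2 `Nc1nc(Cl)nc2c1ncn2[C@@H]1O[C@H]([C@H](O)CO)[C@@H](O)[C@H]1O` in this assay: compound 2 gives > 100000 nM, a limit of the assay.
Compound 3 `CC(=O)OC[C@@H](OC(C)=O)[C@H]1O[C@@H](n2cnc3c(Cl)nc(Cl)nc32)[C@H](OC(C)=O)[C@@H]1OC(C)=O` in this assay: compound 3 gives 16100 nM.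

Compound 3 is the only one of the three with a number; the other two sit at the limit of > 100000 nM in this assay, at which 2 of the 3 values shown sit. The change from compound 1 to compound 2 is amino in place of chloro on an aromatic carbon, and its step that the two limits leave unreadable from compound 1 to compound 2 cannot be read because both ends are limits. Within the data shown here, how the core of compound 3 differs from that of compound 1 is not broken down here; the values show only that compound 3 reaches a number where compound 1 does not.

Compound 4 `CC(=O)OC[C@@H](OC(C)=O)[C@H]1O[C@@H](n2cnc3c(N)nc(Cl)nc32)[C@H](OC(C)=O)[C@@H]1OC(C)=O` is not yet measured. It differs from compound 3 by amino in place of chloro on an aromatic carbon, the same change as that from compound 1 to compound 2. No size can be carried over from that earlier step, since it is unreadable. The expected step is therefore set with little support at a 2.5-fold higher number from compound 3 to compound 4 (0.40 log units; beyond the scatter), leaning toward a weaker inhibitor. Compound 4 is expected near 40000 nM in this assay, within a wide band from 8000 nM to 200000 nM.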

Compound 4, half-maximal inhibitory concentration: > 100000 nM
Compound 4 was reported as a limit (the forecaster's own chance of this, stated with the estimate: 40%); middle value at least 2.5-fold (0.39 log units) away from the limit.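

In this assay, amino in place of chloro on an aromatic carbon of the core of compound 3 gives an at least 6.2-fold higher number from compound 3 to compound 4 (0.79 log units; beyond the scatter), so on this core the change leads to a weaker inhibitor. Compound 4 gives > 100000 nM, a limit of the assay, which makes the step a lower bound and leaves its true size unread. The same change on the core of compound 1 cannot be read, and no size can be compared between the two cores, because both ends of that step stand at the same limit: the limit of > 100000 nM in this assay, at which 3 of the 4 values shown sit.

Going by these compounds, it remains open whether a group other than amino at that aromatic carbon, such as methoxy or a methylamine, would keep a number in this assay on the core of compound 3. On these data alone, it also remains open how the value of compound 3 would respond if its acetyl esters were replaced by a longer chain, such as butyryl esters.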